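The source may hold more compounds than are shown below. What is called first, only, known or untested is meant among the compounds shown, and "the series" means these compounds.

Working notes on the series. Compound 1 `Nc1cc(N)c2nc(-c3ccccc3)c(Oc3ccc(Cl)c(Cl)c3)nc2c1` in a functional assay on SF-295 cells (Homo sapiens) for inhibition, read by sulforhodamine B assay, with a stated time of 48 h (a higher number here means a weaker inhibitor of growth, a lower number a stronger inhibitor of growth), gives 13800 nM, and among the three numbers at hand it stands second highest. Compound 3 `CCOC(=O)[C@H](CCC(=O)O)NC(=O)c1ccc(Oc2nc3cc(N)cc(N)c3nc2-c2ccccc2)cc1` gives 40700 nM in this assay, the nearest value to compound 1 and a higher one. Compound 2 `COc1cc(CNc2nc3cc(N)cc(N)c3nc2-c2ccccc2)cc(OC)c1OC` gives 1660 nM in this assay, the lowest of the three and the furthest from compound 1. Within the data shown here, none of the measured compounds differ from one another in a single place, so the values of compound 2 and compound 3 show only where they sit and define no step.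

Compound 4 `Nc1cc(N)c2nc(-c3ccccc3)c(Oc3ccc(F)cc3)nc2c1` has not been measured. Against compound 1 the difference is 4-fluorophenyl in place of 3,4-dichlorophenyl on an oxygen on an aromatic ring. Among the measured compounds shown here, no comparable change has been measured, so no measured step guides the direction. The expected step of a 1.4-fold higher number from compound 1 to compound 4 (0.16 log units; within the scatter) is a modest one, likely within or near the scatter, leaning toward a slightly higher number. Compound 4 is estimated in this assay at 20000 nM, with a range from 7000 nM to 55000 nM.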

Compound 4, concentration for 50% growth inhibition: 20400 nM
Compound 4: middle estimate off by 1.0-fold (0.01 log units), on the low side; the measured number falls inside the stated range.
By their numbers in this assay, from the lowest: compound 2; then compounds 1, 4 and 3 (each within the scatter of the next, the first and the last beyond it).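

In this assay, among these compounds, 4-fluorophenyl in place of 3,4-dichlorophenyl on an oxygen on an aromatic ring gives a 1.5-fold higher number from compound 1 to compound 4 (0.17 log units; within the scatter), the first step that can be read at this place. At this place, then, the two halogen-bearing phenyl groups are not told apart by this read-out, even though one carries two chlorine atoms and the other a single fluorine. Nothing at hand bears on the origin of this result.

With a single step read here, no trend across substituents on this phenyl ring can be stated. On these data alone, how an unsubstituted phenyl, a 4-methoxyphenyl or a 4-trifluoromethylphenyl would read on this oxygen stays open, as does the effect of a sulfur in place of the oxygen itself.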